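Removing the nitro group from compound 2

The source may hold more compounds than are shown below. What is called first, only, known or untested is meant among the compounds shown, and "the series" means these compounds.

Among the compounds with values here, compound 2 `COc1ccc(/C=C2\Cc3c(cc(OC)c(OC)c3OC)C2=O)cc1[N+](=O)[O-]` has the highest of the two numbers measured so far: in a functional assay on PC-3 cells (Homo sapiens) for antiproliferative activity, read by MTT assay, with a stated time of 48 h (on this read-out higher numbers stand for weaker inhibition of growth and lower numbers for stronger inhibition of growth), compound 2 gives 1560 nM. Its nearest neighbour is compound 1 `COc1ccc(/C=C2\Cc3c(cc(OC)c(OC)c3OC)C2=O)cc1O`, which carries hydroxy where compound 2 carries nitro; in this assay compound 1 gives 213 nM. Within the data shown here, the single measured step, a 7.3-fold higher number from compound 1 to compound 2 (0.86 log units; beyond the scatter), is beyond the scatter and is the only step that bears on the change at hand.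

Compound 3 `COc1ccc(/C=C2\Cc3c(cc(OC)c(OC)c3OC)C2=O)cc1` is not yet measured. It differs from compound 2 by hydrogen in place of nitro on an aromatic carbon. The nitro group leaves and no group takes its place, so the known step helps only partly: it shows that nitro at this place gives a higher number than hydroxy, but nothing measured tells how hydrogen compares with either. For compound 3 the expected step is a 3.1-fold lower number from compound 2 to compound 3 (0.49 log units; beyond the scatter), a fall that may not reach the number of compound 1. For compound 3 in this assay the estimate is 500 nM, with a range from 150 nM to 1500 nM.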

Compound 3, concentration for 50% growth inhibition: 750 nM
Estimate against measurement, compound 3: 1.5-fold (0.18 log units) below; the range from low to high includes it.
By their numbers in this assay, from the lowest: compound 1; then compound 3; then compound 2.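

With hydrogen on this aromatic carbon, the position now has three measured states in this assay, and from the lowest number to the highest they run hydroxy, hydrogen, nitro. Taking the nitro group away gives a 2.1-fold lower number from compound 2 to compound 3 (0.32 log units; beyond the scatter) and so places nitro on the weaker side of the unsubstituted carbon, while replacing the hydroxy group with hydrogen gives a 3.5-fold higher number from compound 1 to compound 3 (0.55 log units; beyond the scatter) and so places hydroxy on the stronger side; the single gap known before thus divides into two separate steps, with hydrogen lying between the two substituents on this read-out. Nothing on hand explains either step.

The compounds shown leave open how other groups on this carbon compare with hydroxy and hydrogen, for example an amine, a fluorine atom or a carboxylic acid, and so whether hydroxy is unusual here or one of several groups that give lower numbers than hydrogen. They also leave open whether the same order of hydroxy, hydrogen and nitro would hold with any other change made to the shared core.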